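Acetyl to dimethylamino on the outer phenyl ring

The compounds below may be only part of what the source reports. "The series", "measured", "known", "first", "only" and "open" are said of these compounds alone.

Compound 1 `COc1cc(C)cc(-c2c(-c3ccnc(-c4ccc(C(C)=O)cc4)c3)cnn2CC#N)c1` and compound 2 `COc1cc(C)cc(-c2nn(CC#N)cc2-c2ccc(-c3cccc(C(C)=O)c3)nc2)c1` share a common core and carry an acetylphenyl group on the pyridine, placed differently in the two. In a functional assay on OVCAR-4 cells (Homo sapiens) for inhibition, read by sulforhodamine B assay, with a stated time of 48 h (a lower number here means a stronger inhibitor of growth, a higher number a weaker inhibitor of growth), compound 1 gives 5130 nM, and compound 2 gives 3760 nM. Compound 1 holds the higher of the two numbers, but its gap to compound 2 lies within the usual scatter, so the two values show no separation that can be read as a difference in growth inhibition.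

Compound 3 `COc1cc(C)cc(-c2c(-c3ccnc(-c4ccc(N(C)C)cc4)c3)cnn2CC#N)c1` is the unmeasured partner of compound 1. The change from compound 1 to compound 3 is dimethylamino in place of acetyl on an aromatic carbon, keeping the rest of the molecule untouched. Among the measured compounds shown here, no measured pair shows what this exchange does, so there is no step on record to lean on, and no direction can be argued from the data.

With nothing in the numbers to point either way, compound 3 is expected to stay close to compound 1, that is a step of a 1.1-fold lower number from compound 1 to compound 3 (0.06 log units; within the scatter) not beyond the scatter. Compound 3 is therefore estimated at 4500 nM, within 1400 nM to 14000 nM.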

Compound 3, concentration for 50% growth inhibition: 270 nM
The estimate for compound 3 lay 17-fold (1.22 log units) above the measured number; measured number below the stated range.
By their numbers in this assay, from the lowest: compound 3; then compounds 2 and 1 (each within the scatter of the next).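

Among the compounds shown here, the step of a 19-fold lower number from compound 1 to compound 3 (1.28 log units; beyond the scatter) in this assay gives the first reading on this position: the substituent para to a large group on the outer phenyl ring has a large bearing on growth inhibition, which the two acetyl compounds alone could not show. The exchange leaves the counts of heavy atoms, hydrogen-bond donors and hydrogen-bond acceptors unchanged, and neither group carries a net charge, so these counts do not separate acetyl from dimethylamino; the recorded differences are the oxygen against the nitrogen and the double bond outside aromatic rings that leaves with acetyl. No measurement on this series gives a reason for the size of the step.

As far as these compounds go, whether the gain is particular to dimethylamino or extends to other groups at this carbon, such as a primary amine, a pyrrolidine ring, a morpholine ring or a methoxy group, remains open. Also open, from the compounds shown here alone, is whether the same exchange carries over to the acetyl of compound 2, where the acetylphenyl group is placed differently.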